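Chloro in place of fluoro on compound 2

A few compounds are considered here, and "the series" means these few. Any claim that something is new, unique, unknown or untested is made for them only; others in the source may bear on it.

Two close relatives, compound 1 `O=C(NN1Cc2ccccc2C1)c1cc([N+](=O)[O-])ccc1F` and compound 2 `O=C(NN1CCc2ccccc2C1)c1cc([N+](=O)[O-])ccc1F`, have been tested in an ADME assay on L6 cells (Rattus norvegicus) for cytotoxicity; on this read-out lower numbers stand for stronger inhibition and higher numbers for weaker inhibition. Compound 1 gives > 331000 nM, which is a limit of the assay and not a number. Compound 2 gives > 317000 nM, which is likewise a limit and not a number. Compound 2 therefore has no exact place on the scale, and the only other result beside it is also a limit. Among the measured compounds shown here, no measured step between compounds is available as a guide.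

Compound 3 `O=C(NN1CCc2ccccc2C1)c1cc([N+](=O)[O-])ccc1Cl` differs from compound 2 in one place: chloro in place of fluoro on an aromatic carbon. The swap leaves the rest of the structure untouched, and the new halogen sits ortho to a large group and para to a nitro group.

Any forecast is a judgement. A small move towards stronger inhibition seems likely, and a result that again reaches a limit would be no surprise. The expected step is an at least 1.7-fold lower number from compound 2 to compound 3 (0.24 log units; that floor lies within the scatter). For compound 3 the estimated value is 180000 nM, with an expected range from 60000 nM to 320000 nM.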

Compound 3, half-maximal inhibitory concentration: 22000 nM
Compound 3: middle estimate off by 8.2-fold (0.91 log units), on the high side, and the stated range ends above it.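

Swapping fluoro for chloro at this place on the aromatic ring, ortho to a large group and para to a nitro group, has a large effect in this assay: the change gives an at least 14-fold lower number from compound 2 to compound 3 (1.15 log units; beyond the scatter). Compound 1 and compound 2 have no exact place on the scale, so they gave no sign that this position could matter, whereas compound 3 provides the first measured number among the compounds shown. The step has only a floor and no exact size, because the starting point for compound 2 is a limit of the assay and not a number: the limit of > 317000 nM in this assay, at which 1 of the 3 values shown sits.

One swap cannot tell whether the stronger inhibition belongs to chloro alone or would also appear with bromo, methyl or methoxy at the same place, and nothing shown explains how the change produces it. The same chloro swap on compound 1 would show whether the effect carries over to the core of that compound, which differs from the core of compound 2.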